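A few compounds are considered here, and "the series" means these few. Any claim that something is new, unique, unknown or untested is made for them only; others in the source may bear on it.

Compound 1 `COc1ccc(/C=N\NC(=S)NC(C)(C)CCC[C@](C)(O)[C@@H]2CC=C(C)CC2)cc1` gives 76100 nM in a functional assay on PCO3 cells (Homo sapiens) for cytotoxicity, read by sulforhodamine B assay; on this read-out lower numbers stand for stronger inhibition of growth and higher numbers for weaker inhibition of growth. Compound 2 `CC1=CC[C@@H]([C@@](C)(O)CCCC(C)(C)NC(=S)N/N=C\c2ccc(O)cc2)CC1` gives 13900 nM in this assay. Compound 3 `CC1=CC[C@@H]([C@@](C)(O)CCCC(C)(C)NC(=S)N/N=C\c2ccc([N+](=O)[O-])cc2)CC1` is reported in this assay only as > 100000 nM, a limit of the assay.

Compound 3 thus stands at the limit of > 100000 nM in this assay, at which 1 of the 3 values shown sits, the weakest end of the three. Its step from compound 2 is an at least 7.1-fold higher number from compound 2 to compound 3 (0.85 log units; beyond the scatter), so compound 3 gives a clearly higher number than compound 2. Its step from compound 1 is an at least 1.3-fold higher number from compound 1 to compound 3 (0.11 log units; that floor lies within the scatter), so compound 3 and compound 1 cannot be separated on this read-out. Among the measured compounds, the step of a 5.5-fold lower number from compound 1 to compound 2 (0.74 log units; beyond the scatter) is the only one settled beyond scatter in the downward direction.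

Compound 4 `CC1=CC[C@@H]([C@@](C)(O)CCCC(C)(C)NC(=S)N/N=C\c2cccc(Cl)c2)CC1` differs from compound 3 by 3-chlorophenyl in place of 4-nitrophenyl on a carbon with a double bond to nitrogen. Among the compounds with values here, no measured step swaps the nitro for a chloro or moves a substituent around the ring, so the bearing evidence is indirect: all three measured compounds vary only this aromatic substituent, and the nitro compound 3 sits at the limit while compound 1 and compound 2 give numbers. The step from compound 3 to compound 4 is therefore expected to bring the number back into the measured range, though by an amount that cannot be fixed from the data. Compound 4 is expected at 40000 nM, within 10000 nM to 150000 nM. This estimate means an expected at least 2.5-fold lower number from compound 3 to compound 4 (0.39 log units; beyond the scatter).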

Compound 4, concentration for total growth inhibition: 37800 nM
The estimate for compound 4 lay 1.1-fold (0.02 log units) above the measured number, and the stated range covers the measured number.
By their numbers in this assay, from the lowest: compound 2; then compounds 4 and 1 (each within the scatter of the next). At a limit, above all of these: compound 3.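

Replacing the 4-nitrophenyl group with 3-chlorophenyl on a carbon with a double bond to nitrogen brings the series back to a measurable number in this assay (an at least 2.6-fold lower number from compound 3 to compound 4 (0.42 log units; beyond the scatter)), so this position does not need an oxygen-bearing group on the aromatic ring to give a number in the measured range. Compound 3 itself is reported only at a limit of the assay: the limit of > 100000 nM in this assay, at which 1 of the 4 values shown sits. The 3-chlorophenyl group cannot be separated from 4-methoxyphenyl (a 2.0-fold lower number from compound 1 to compound 4 (0.30 log units; within the scatter)), but it falls short of 4-hydroxyphenyl (a 2.7-fold higher number from compound 2 to compound 4 (0.43 log units; beyond the scatter)), which leaves compound 2 with the lowest number of the four, its steps to the other three all lying beyond the scatter.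

From the compounds shown here alone, whether the lower number follows the chlorine itself or its place on the aromatic ring stays open, for the four compounds never vary one without the other. They also leave open how this read-out would respond to an amine or a carboxylic acid on the aromatic ring.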